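Ring Closure on the Carbamate Ester: Expecting Compound 4

A few compounds are considered here, and "the series" means these few. Any claim that something is new, unique, unknown or untested is made for them only; others in the source may bear on it.

All three measured compounds were tested in a functional assay on isolated protein for inhibition of Glucose-dependent insulinotropic receptor (Rattus norvegicus), read by HTRF and cAMP accumulation; a lower number here means a smaller maximal response, a higher number a larger maximal response:
compound 1 `Cc1nc(S(C)(=O)=O)ccc1Oc1ncnc(OC2CCN(C(=O)O[C@H](C)CF)CC2)c1F` gives 79%
compound 2 `Cc1nc(S(C)(=O)=O)ccc1Oc1ncnc(OC2CCN(C(=O)O[C@@H](C)CF)CC2)c1F` gives 84%
compound 3 `Cc1nc(S(C)(=O)=O)ccc1Oc1ncnc(OC2CCN(C(=O)O[C@@H](C)C(F)(F)F)CC2)c1F` gives 80%

Compound 3 lies between the numbers of compound 1 and compound 2, and the steps of a number 1 percentage points higher from compound 1 to compound 3 (within the scatter) and a number 4 percentage points lower from compound 2 to compound 3 (within the scatter) are both within the scatter, so the three compounds cannot be told apart on this read-out. The step of a number 5 percentage points higher from compound 1 to compound 2 (within the scatter) is also within the scatter, and the fact that compounds 1 and 2 differ only in the configuration as drawn shows that those two compounds are the same in every respect except the drawn configuration.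

The new compound 4 `Cc1nc(S(C)(=O)=O)ccc1Oc1ncnc(OC2CCN(C(=O)OC3(C(F)(F)F)CCC3)CC2)c1F` changes the group on the oxygen of the carbamate: 1-(trifluoromethyl)cyclobutyl in place of 1-(trifluoromethyl)ethyl on an oxygen next to a carbonyl group. The measured steps that bear on this place are a number 4 percentage points lower from compound 2 to compound 3 (within the scatter) and a number 1 percentage points higher from compound 1 to compound 3 (within the scatter), both within the scatter, so altering the substituent at this oxygen has so far left the maximal response unchanged. For the measured compounds named here, nothing among the measured compounds suggests that a ring at this position would behave differently. The step of no change at the digits printed from compound 3 to compound 4 (within the scatter) is therefore expected to fall within the scatter. Compound 4 is estimated at 80%, with a range from 66% to 92%.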

Compound 4, largest response reached (reported as efficacy), in percent of the reference or control that the assay uses: 82%
Estimate against measurement, compound 4: 2 percentage points below; measured number inside the range.
By their numbers in this assay, from the lowest: compounds 1, 3, 4 and 2 (each within the scatter of the next).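

In this assay, for the compounds shown here, the earlier compounds varied only the fluorine on an open chain and the drawn configuration, whereas the step of a number 2 percentage points higher from compound 3 to compound 4 (within the scatter) tests a group carrying a ring: 1-(trifluoromethyl)cyclobutyl, with its four-membered ring of carbon only, on an oxygen next to a carbonyl group. The comparisons with the two fluoromethyl compounds agree, with a number 2 percentage points lower from compound 2 to compound 4 (within the scatter) and a number 3 percentage points higher from compound 1 to compound 4 (within the scatter), so among these four compounds neither the added ring nor the larger group gives a readable change in maximal response. Going by these compounds alone, the new group also has no defined stereocentre, and configuration at this place had already given no readable difference in the one pair that can test it: the fact that compounds 1 and 2 differ only in the configuration as drawn.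

Every group shown here is a fluorinated carbon group, so it remains open how this read-out would respond to a plain tert-butyl group without fluorine, or to a group carrying an amine or a carboxylic acid. Going by these compounds, it is also open whether a larger ring such as cyclohexyl would stay as close to these four compounds as the cyclobutyl group does.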